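This account rests on a few compounds, and the source may have more. Where it says the series, first, only, none or still open, it means among the compounds named here.

Measured so far:
- compound 1, `O=C(Nc1nc2ccc([N+](=O)[O-])cc2s1)c1cccnc1Nc1ccccc1`, giving 580 nM in a functional assay on HL-60 cells (Homo sapiens) for inhibition, read by MTT assay, with a stated time of 48 h; a higher number here means a weaker inhibitor, a lower number a stronger inhibitor
- compound 2, `O=C(Nc1nc2ccc([N+](=O)[O-])cc2s1)c1cccnc1Nc1cc(F)c(F)c(F)c1`, giving 80 nM in this assay
- compound 3, `O=C(Nc1nc2ccc([N+](=O)[O-])cc2s1)c1cccnc1Nc1ccc(F)cc1`, giving 300 nM in this assay

Compound 3 stands second highest of the three numbers. Its nearest neighbour is compound 1, the step being a 1.9-fold lower number from compound 1 to compound 3 (0.29 log units; within the scatter). The furthest is compound 2, the step being a 3.8-fold higher number from compound 2 to compound 3 (0.57 log units; beyond the scatter).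

Compound 4, `O=C(Nc1nc2ccc([N+](=O)[O-])cc2s1)c1cccnc1Nc1ccc(Cl)cc1`, differs from compound 3 by chloro in place of fluoro on an aromatic carbon. For the measured compounds named here, no measured step exchanges one halogen for another on that ring. The step of a 1.9-fold lower number from compound 1 to compound 3 (0.29 log units; within the scatter) shows that adding this fluoro changed little, while a 7.3-fold lower number from compound 1 to compound 2 (0.86 log units; beyond the scatter) and a 3.8-fold higher number from compound 2 to compound 3 (0.57 log units; beyond the scatter) concern the count of fluorines rather than their kind. On this basis no step beyond the scatter is expected in this assay, with the direction left open.

Compound 4 is therefore estimated at 250 nM, with a range from 100 nM to 650 nM, which means an expected step of a 1.2-fold lower number from compound 3 to compound 4 (0.08 log units; within the scatter).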

Compound 4, half-maximal inhibitory concentration: 400 nM
The estimate for compound 4 lay 1.6-fold (0.20 log units) below the measured number, and the stated range covers the measured number.
By their numbers in this assay, from the lowest: compound 2; then compounds 3, 4 and 1 (each within the scatter of the next).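

At this position, para to a large group, the kind of halogen made no readable difference in this assay, with chloro in place of fluoro giving a 1.3-fold higher number from compound 3 to compound 4 (0.12 log units; within the scatter) and a step within the scatter. Chloro in place of hydrogen, at a 1.5-fold lower number from compound 1 to compound 4 (0.16 log units; within the scatter), likewise stayed within the scatter, so neither single halogen shown separates from the phenyl group. The 3,4,5-trifluorophenyl group remains apart from the 4-chlorophenyl group, at a 5.0-fold higher number from compound 2 to compound 4 (0.70 log units; beyond the scatter), and every step beyond the scatter in this set runs through that trifluorinated ring; nothing available bears on the cause of these numbers.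

Going by these compounds, it remains open whether a methyl, a methoxy, a nitrile or an amine in this place would stay as close to the halogens. Also open, on these data alone, is whether the fluoro groups on the trifluorinated ring act together or one of them accounts for its steps.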